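Swapping Amide for Acid on an Inactive Chain

A few compounds are considered here, and "the series" means these few. Any claim that something is new, unique, unknown or untested is made for them only; others in the source may bear on it.

Compound 1 `NC(=O)c1cccc(CN(CCCCC(=O)O)C[C@H]2O[C@@H](n3cnc4c(N)ncnc43)[C@H](O)[C@@H]2O)c1` was tested in an assay on cells for inhibition of Nicotinamide N-methyltransferase (Homo sapiens), with stated times of 10 min and 30 min; on this read-out lower numbers stand for stronger inhibition and higher numbers for weaker inhibition. In this assay compound 1 reaches only a limit, > 250000 nM. Compound 2 `COC(=O)c1cccc(CN(CCCCC(=O)O)C[C@H]2O[C@@H](n3cnc4c(N)ncnc43)[C@H](O)[C@@H]2O)c1` carries a methoxy in place of amino on a carbonyl carbon. In this assay compound 2 likewise gives only a limit, > 250000 nM. The change a step that the two limits leave unreadable from compound 1 to compound 2 therefore cannot be sized. Compound 3 `NC(=O)CCCCN(Cc1cccc(C(=O)O)c1)C[C@H]1O[C@@H](n2cnc3c(N)ncnc32)[C@H](O)[C@@H]1O` is also known only as a limit in this assay, > 250000 nM. Compound 4 `Nc1ncnc2c1ncn2[C@@H]1O[C@H](CN(CCCCC(=O)O)Cc2cccc(C(=O)O)c2)[C@@H](O)[C@H]1O` differs from compound 3 by hydroxy in place of amino on a carbonyl carbon. For the measured compounds named here, no measured step bears on this change, since every value shown sits at the limit (the limit of > 250000 nM in this assay, at which 3 of the 3 values shown sit). The step from compound 3 to compound 4 is therefore expected to be a step that the limit leaves unreadable from compound 3 to compound 4, meaning no inhibition detectable beyond the limit. Compound 4 is expected to give 300000 nM, between 100000 nM and 1000000 nM, most likely again a limit.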

Compound 4, half-maximal inhibitory concentration: > 250000 nM
Compound 4: only a limit was reported; the forecaster's own chance of this, stated with the estimate: 85%; the middle value does not contradict the limit.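

Compound 4 sits at a limit, as do compound 1, compound 2 and compound 3, so none of the steps among them can be read: the limit of > 250000 nM in this assay, at which 4 of the 4 values shown sit. The compounds shown leave open which change to the shared core would give a measured number in this assay rather than a limit.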